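The source may hold more compounds than are shown below. What is called first, only, known or untested is meant among the compounds shown, and "the series" means these compounds.

Measured compounds:
compound 1, `OC1CN(Cc2ccccc2)CCC1N1CCN(c2ccccc2)CC1`: in an assay on PC-12 cells for displacement of a labelled ligand from vesicular acetylcholine transporter (Homo sapiens) (on this read-out lower numbers stand for stronger inhibition and higher numbers for weaker inhibition), compound 1 gives 57 nM
compound 2, `OC1CN(Cc2ccc(Br)cc2)CCC1N1CCN(c2ccccc2)CC1`: in this assay compound 2 gives only a limit, > 100 nM

Within the data shown here, compound 1 holds the only number reported in this assay; the other entry is a limit. For compound 2 the entry sits at the limit of > 100 nM in this assay, at which 1 of the 2 values shown sits. Among the measured compounds shown here, the one measured step, an at least 1.7-fold higher number from compound 1 to compound 2 (0.24 log units; that floor lies within the scatter), comes from bromo in place of hydrogen on an aromatic carbon, and its floor lies within the scatter.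

Compound 3, `C=CCN1CCC(N2CCN(c3ccccc3)CC2)C(O)C1`, differs from compound 1 by vinyl in place of phenyl on a saturated chain carbon bound to an amine nitrogen in a ring. For the measured compounds named here, no measured step removes the phenyl of the benzyl group; the only step alters a substituent on that ring and gives no direct guide here. The replacement of an aromatic ring by a short chain is expected to weaken binding, so the estimated step is a 4.4-fold higher number from compound 1 to compound 3 (0.64 log units; beyond the scatter). Compound 3 is therefore estimated at 250 nM in this assay, with an expected range from 60 nM to 1500 nM.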

Compound 3, half-maximal inhibitory concentration: > 100 nM
Compound 3 gave a limit, no number (the forecaster's own chance of this, stated with the estimate: 65%); the middle value does not contradict the limit.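

At this position, on a saturated chain carbon bound to an amine nitrogen in a ring, vinyl in place of phenyl gives an at least 1.7-fold higher number from compound 1 to compound 3 (0.24 log units; that floor lies within the scatter), so benzyl to allyl is not yet shown to change the result beyond the scatter. In this assay compound 3 gives only a limit, > 100 nM. Changes to the benzyl group, whether bromo on its ring or allyl in its place, have so far given no second number, and the step between the two limit compounds cannot be read: the limit of > 100 nM in this assay, at which 2 of the 3 values shown sit.

On these data alone, the true size of the change from benzyl to allyl stays open, as does the order of compound 2 and compound 3. Also open, as far as these compounds go, is whether a saturated propyl group, a longer chain or a benzyl group carrying methoxy in place of bromo would give a number in this assay.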